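A Fluoro Group Added at the Assay Limit

This account rests on a few compounds, and the source may have more. Where it says the series, first, only, none or still open, it means among the compounds named here.

- Compound 1 `O=C(Nc1ccccc1)N1c2ccnn2CC1c1ccccc1`: > 1000 nM
- Compound 2 `CCOC(=O)c1cnn2c1N(C(=O)Nc1ccccc1)C(c1ccccc1)C2`: > 1000 nM

Both entries come from a functional assay on cells (Neutrophil, Homo sapiens) for inhibition, with a stated time of 10 min (a lower number here means a stronger inhibitor, a higher number a weaker inhibitor), and both are limits, not numbers. Compound 2 stands at the limit of > 1000 nM in this assay, at which 2 of the 2 values shown sit. Compound 3 `CCOC(=O)c1cnn2c1N(C(=O)Nc1cccc(F)c1)C(c1ccccc1)C2` differs from compound 2 in one place, where phenyl becomes 3-fluorophenyl: fluoro in place of hydrogen on an aromatic carbon. Among the compounds with values here, the only measured step is a step that the two limits leave unreadable from compound 1 to compound 2. That step concerns ethoxycarbonyl, not fluoro, and it offers no size to carry over. Within the data shown here, with no measured fluoro step to draw on, no particular size or direction can be argued, and a step beyond the scatter is not expected. The expected step, a rough estimate, is a step that the limit leaves unreadable from compound 2 to compound 3. A limit is again the likeliest report for compound 3 in this assay. As a number, the estimate for compound 3 is 2000 nM, with an expected range from 300 nM to 10000 nM.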

Compound 3, half-maximal inhibitory concentration: 111 nM
The estimate for compound 3 lay 18-fold (1.26 log units) above the measured number; the measured number lies below the stated range.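

In this assay, the change of phenyl to 3-fluorophenyl gives an at least 9.0-fold lower number from compound 2 to compound 3 (0.95 log units; beyond the scatter). This shows that the place on this six-membered aromatic ring, meta to a large group, responds strongly to a change: a single added fluorine atom is enough to bring a compound from a limit to a readable number. Compound 2 is reported only as a limit, so the size of the step is a floor rather than an exact figure: the limit of > 1000 nM in this assay, at which 2 of the 3 values shown sit.

The compounds shown leave open whether a chloro or methoxy group at this place would have the same effect, or whether fluoro must sit at exactly this place on the ring. They also leave open whether the fluoro step would hold on the core of compound 1, which lacks the ethoxycarbonyl group.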